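Cyano in Place of Fluoro on a Shared Amide Core

The source may report more compounds than this note shows. Statements on the series, on what has been measured and on what is new or still open speak of the compounds shown alone.

Measured compounds:
compound 1 `N#Cc1cc(Cl)ccc1NC(=O)c1ccc2cccnc2c1O`: 280 nM
compound 2 `N#Cc1ccc(NC(=O)c2ccc3cccnc3c2O)c(Cl)c1`: 420 nM
compound 3 `N#Cc1ccc(NC(=O)c2ccc3cccnc3c2O)c(F)c1`: 370 nM

Of the compounds shown here, three built on the same core have been tested in a functional assay on NALM-6 cells (Homo sapiens) for cytotoxicity, read by luminescence and CellTiter-Glo, with a stated time of 3 days; on this read-out higher numbers stand for weaker inhibition and lower numbers for stronger inhibition. Compound 3 gives the second highest of the three numbers; its nearest neighbour is compound 2, and the furthest is compound 1, yet both gaps are within the scatter, so the three cannot be ranked against one another on these numbers.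

The next compound is compound 4 `N#Cc1ccc(NC(=O)c2ccc3cccnc3c2O)c(C#N)c1`, which differs from compound 3 in one place: cyano in place of fluoro on an aromatic carbon.

For the measured compounds named here, only one measured step speaks to a change at this position. It is a 1.1-fold lower number from compound 2 to compound 3 (0.06 log units; within the scatter), a swap of one small group for another at the same aromatic carbon that left the number essentially unchanged. Going by the values given here, a cyano group is a different kind of substituent from either chloro or fluoro, and there is no measured example of it at this position, so the single step gives only a weak guide. Compound 4 is therefore expected to land close to compound 3, with no step beyond the scatter likely, as a 1.1-fold higher number from compound 3 to compound 4 (0.03 log units; within the scatter). The estimate for compound 4 is 400 nM, with a range from 150 nM to 1100 nM.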

Compound 4, half-maximal inhibitory concentration: 350 nM
Compound 4: the middle estimate sits 1.1-fold (0.06 log units) above what was measured, and the stated range covers the measured number.
By their numbers in this assay, from the lowest: compounds 1, 4, 3 and 2 (each within the scatter of the next).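

In this assay, a cyano group at this aromatic carbon, ortho to a large group, reads like the halogens it replaces, with a 1.1-fold lower number from compound 3 to compound 4 (0.02 log units; within the scatter) and a 1.2-fold lower number from compound 2 to compound 4 (0.08 log units; within the scatter). So three different groups have now stood at this carbon without any step beyond the scatter, and a group with a triple bond and a hydrogen-bond acceptor fits the same picture as fluoro and chloro. The third comparison concerns a chloro at a different aromatic carbon, with cyano in its place giving a 1.3-fold higher number from compound 1 to compound 4 (0.10 log units; within the scatter), so that change also stays within the scatter, and no information is available to explain why these numbers stay so close.

The compounds shown carry only chloro, fluoro and cyano at these carbons, so it remains open whether an amine, a carboxylic acid or a longer chain there would move the number beyond the scatter. They also leave open whether a methyl group in place of the amide hydrogen, or any change to the shared core, would matter more than these swaps on the outer ring.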